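Replacing the bicyclic aryl of compound 3 with pyrazolyl

The source may report more compounds than this note shows. Statements on the series, on what has been measured and on what is new or still open speak of the compounds shown alone.

Measured so far in an assay on C3H 10T1/2 cells for inhibition of Sonic hedgehog protein (Mus musculus), read by a luciferase reporter; on this read-out lower numbers stand for stronger inhibition and higher numbers for weaker inhibition:
compound 1 `Cc1nc(C(F)(F)F)ccc1C(=O)Nc1ccc(Cl)c(-c2cc3ccccc3[nH]2)c1`: 500 nM
compound 2 `Cc1nc(C(F)(F)F)ccc1C(=O)Nc1ccc(Cl)c(-c2nc3ccccc3s2)c1`: 70 nM
compound 3 `Cc1nc(C(F)(F)F)ccc1C(=O)Nc1ccc(Cl)c(-c2cn3ccsc3n2)c1`: 200 nM

Compound 3 stands second highest of the three numbers in this assay. The steps to it are a 2.5-fold lower number from compound 1 to compound 3 (0.40 log units; beyond the scatter) and a 2.9-fold higher number from compound 2 to compound 3 (0.46 log units; beyond the scatter); the remaining measured step is a 7.1-fold lower number from compound 1 to compound 2 (0.85 log units; beyond the scatter).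

Compound 4 is `Cc1nc(C(F)(F)F)ccc1C(=O)Nc1ccc(Cl)c(-n2cccn2)c1`. Its change from compound 3 is a group of 5 heavy atoms (3 carbon, 2 nitrogen; one five-membered aromatic ring with 2 hetero atoms) in place of a group of 8 heavy atoms (5 carbon, 2 nitrogen, 1 sulfur; 2 five-membered aromatic rings with 2 hetero atoms each), on an aromatic carbon. Among the compounds with values here, every measured step exchanges one bicyclic group at this position for another bicyclic group; none removes a ring, so no measured step bears directly on this change. The measured steps show that this position is sensitive, with differences beyond the scatter in each direction. Without a direct precedent, a modest rise in the number is expected for compound 4, since the entering group is the smallest tried at this position, with wide uncertainty, that is a 2.3-fold higher number from compound 3 to compound 4 (0.35 log units; beyond the scatter). Compound 4 is estimated at 450 nM, in the range 100 nM to 2500 nM.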

Compound 4, half-maximal inhibitory concentration: 450 nM
Compound 4: middle estimate and measured number agree at the digits printed; the measured number falls inside the stated range.
By their numbers in this assay, from the lowest: compound 2; then compound 3; then compounds 4 and 1 (each within the scatter of the next).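

Within the data shown here, the first single-ring group at this position, 1H-pyrazol-1-yl, gives a 2.3-fold higher number from compound 3 to compound 4 (0.35 log units; beyond the scatter) and the larger 6.4-fold higher number from compound 2 to compound 4 (0.81 log units; beyond the scatter) in this assay, so both of these bicyclic groups give lower numbers than the single ring. Against 1H-indol-2-yl, however, the result is a 1.1-fold lower number from compound 1 to compound 4 (0.05 log units; within the scatter), so a second ring does not by itself lower the number: compound 2 and compound 3 fit that trend, while compound 1 goes against it. No measured evidence accounts for these differences.

Going by these compounds, it remains open whether a methyl group or an amine on the pyrazole ring would move the number in this assay. Also open, on these data alone, is whether a single six-membered ring such as pyridyl would match 1H-pyrazol-1-yl.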